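Working notes: swapping the amide group on compound 2

The source may report more compounds than this note shows. Statements on the series, on what has been measured and on what is new or still open speak of the compounds shown alone.

Measured in a functional assay on A20 cells (Mus musculus) for inhibition, with stated times of 1 h, 16 h and 24 h; on this read-out higher numbers stand for weaker inhibition and lower numbers for stronger inhibition:
- compound 1 `N#CC1(NC(=O)[C@@H]2C[C@@H](S(=O)(=O)c3ccccc3)C[C@H]2C(=O)N2CCOCC2)CCC1` gives 236 nM
- compound 2 `N#CC1(NC(=O)[C@@H]2C[C@@H](S(=O)(=O)c3ccccc3)C[C@H]2C(=O)N2CC3CCC(C2)O3)CC1` gives 16 nM

Compound 2 holds the lower of the two numbers, and its gap to compound 1 lies beyond the scatter. Among the measured compounds shown here, the two compounds differ in more than one place, so the measured data contain no single-change step.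

Compound 3 `N#CC1(NC(=O)[C@@H]2C[C@@H](S(=O)(=O)c3ccccc3)C[C@H]2C(=O)N2CCC(O)CC2)CC1` has not yet been measured. It departs from compound 2 in one place, on a carbonyl carbon: a group of 7 heavy atoms (5 carbon, 1 nitrogen, 1 oxygen; one six-membered non-aromatic ring with 1 hetero atom) in place of a group of 8 heavy atoms (6 carbon, 1 nitrogen, 1 oxygen; one five-membered non-aromatic ring with 1 hetero atom, one six-membered non-aromatic ring with 2 hetero atoms), on a carbonyl carbon. For the measured compounds named here, no measured compound carries the 4-hydroxypiperidin-1-yl group, so the direction is uncertain. Going by the values given here, compound 2 at 16 nM is the lower of only two numbers, which makes a rise the likelier outcome. In this assay the expected change is a 2.5-fold higher number from compound 2 to compound 3 (0.40 log units; beyond the scatter), a modest move toward weaker inhibition. For compound 3 the estimated value is 40 nM, with an expected range of 12 nM to 130 nM.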

Compound 3, half-maximal inhibitory concentration: 371 nM
The estimate for compound 3 lay 9.3-fold (0.97 log units) below the measured number; the measured number lies above the stated range.
By their numbers in this assay, from the lowest: compound 2; then compounds 1 and 3 (each within the scatter of the next).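

In this assay the amide group on the carbonyl carbon now has its first single-change reading, and the effect is large: a 23-fold higher number from compound 2 to compound 3 (1.37 log units; beyond the scatter). This position is therefore far from indifferent to the group it carries, and the group of compound 2 cannot be exchanged for 4-hydroxypiperidin-1-yl without a clear loss of inhibition. The step changes several things at once, as the two-ring group leaves and a single-ring group with a hydrogen-bond donor enters, and no measurement at hand bears on what lies behind its size.

Open, going by these compounds, is whether the hydroxyl itself or the loss of the second ring accounts for the step, which a plain piperidin-1-yl or a 4-methoxypiperidin-1-yl group on the same carbonyl carbon could separate. Also open, on these data alone, is how an amine such as 4-aminopiperidin-1-yl would read at this position.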